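The source may report more compounds than this note shows. Statements on the series, on what has been measured and on what is new or still open speak of the compounds shown alone.

Going by the values given here, compound 2 `O=C(CSc1nnc(-c2ccncc2)o1)N/N=C/c1cc(Cl)ccc1O` gives the lower of the two numbers so far in a functional assay on BGC-823 cells (Homo sapiens) for cytotoxicity, read by MTT assay, with a stated time of 48 h (on this read-out higher numbers stand for weaker inhibition and lower numbers for stronger inhibition), at 5470 nM, while compound 1 `O=C(CSc1nnc(-c2ccncc2)o1)N/N=C/c1cccc(F)c1` gives 27500 nM. That single measured step, a 5.0-fold lower number from compound 1 to compound 2 (0.70 log units; beyond the scatter), brought in the hydroxy group that compound 2 carries. Compound 3 `O=C(CSc1nnc(-c2ccncc2)o1)N/N=C/c1cc(Br)cc(Br)c1O` differs from compound 2 by 3,5-dibromo-2-hydroxyphenyl in place of 5-chloro-2-hydroxyphenyl on a carbon with a double bond to nitrogen. Among the compounds with values here, only the step from compound 1 to compound 2 bears on this change, and it kept the hydroxy group while changing the halogen pattern, so no large shift is expected. The step from compound 2 to compound 3 is expected to be a 1.4-fold lower number from compound 2 to compound 3 (0.14 log units; within the scatter). Compound 3 is therefore estimated at 4000 nM, with a range from 1500 nM to 12000 nM.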

Compound 3, half-maximal inhibitory concentration: 9610 nM
Estimate against measurement, compound 3: 2.4-fold (0.38 log units) below; low and high end bracket the measured number.
By their numbers in this assay, from the lowest: compounds 2 and 3 (each within the scatter of the next); then compound 1.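

In this assay, 3,5-dibromo-2-hydroxyphenyl and 5-chloro-2-hydroxyphenyl on the carbon with a double bond to nitrogen cannot be told apart, with a 1.8-fold higher number from compound 2 to compound 3 (0.24 log units; within the scatter) and so no clear effect of the second halogen pattern. Against 3-fluorophenyl, the dibromo group still gives a 2.9-fold lower number from compound 1 to compound 3 (0.46 log units; beyond the scatter) and so joins compound 2 on the lower side of compound 1. Nothing measured here explains these results. The compounds shown leave open whether the hydroxy group or the halogens separate compounds 2 and 3 from compound 1, and what a methoxy group or an amine would do in place of that hydroxy group.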